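The source may hold more compounds than are shown below. What is called first, only, known or untested is meant among the compounds shown, and "the series" means these compounds.

Among the compounds with values here, compound 1 `C/C(C#Cc1ccccc1)=N\N/C(N)=N/S(=O)(=O)c1cc(C)c(Cl)cc1SCc1ccccc1C` is one of two compounds measured in a functional assay on MCF7 cells (Homo sapiens) for antiproliferative activity, read by MTT assay, with a stated time of 72 h (on this read-out lower numbers stand for stronger inhibition and higher numbers for weaker inhibition), where compound 1 gives 150000 nM, the highest of the two numbers. Compound 2 `Cc1cc(S(=O)(=O)/N=C(\N)N/N=C/C#Cc2ccccc2)c(SCc2ccccc2Cl)cc1Cl` gives 15000 nM in this assay, a lower number than compound 1. Compound 3 `C/C(C#Cc1ccccc1)=N\N/C(N)=N/S(=O)(=O)c1cc(C)c(Cl)cc1SCc1cccc(Cl)c1` has not been measured; it differs from compound 1 by 3-chlorophenyl in place of 2-methylphenyl on a saturated chain carbon bound to a sulfur. Within the data shown here, no measured pair shows this change on its own, so the expected step from compound 1 to compound 3 is a modest move toward a lower number, estimated at a 2.1-fold lower number from compound 1 to compound 3 (0.33 log units; beyond the scatter) in this assay. Compound 3 is therefore expected to give about 70000 nM, in a range from 20000 nM to 200000 nM.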

Compound 3, half-maximal inhibitory concentration: 80000 nM
Compound 3: the middle estimate sits 1.1-fold (0.06 log units) below what was measured; the range from low to high includes it.
By their numbers in this assay, from the lowest: compound 2; then compounds 3 and 1 (each within the scatter of the next).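

With the shared core of compound 1 held fixed, placing 3-chlorophenyl in place of 2-methylphenyl on a saturated chain carbon bound to a sulfur gives a 1.9-fold lower number from compound 1 to compound 3 (0.27 log units; within the scatter) in this assay. Within the data shown here, this assay therefore does not separate these two groups at this place, which the earlier compounds could not show. Nothing available explains this result.

The compounds shown leave open whether this place accepts groups of a different kind. An amine or a carboxylic acid on the phenyl ring, or a longer chain before it, might shift the number further.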